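This account rests on a few compounds, and the source may have more. Where it says the series, first, only, none or still open, it means among the compounds named here.

Working notes on the series.

Compound 1 `COCOc1ccc(Cc2ccc3cc(NC(=O)c4ccc(OC(C)=O)c(CC=C(C)C)c4)c(=O)oc3c2C)cc1OC` and compound 2 `COCOc1ccc(Cc2ccc3cc(NC(=O)c4ccc(OC(C)=O)c(CC=C(C)C)c4)c(=O)oc3c2C)cc1` share a core and differ in one place; in a functional assay on MCF7 cells (Homo sapiens) for antiproliferative activity (a higher number here means a weaker inhibitor, a lower number a stronger inhibitor), compound 1 gives 14900 nM and compound 2 gives 22700 nM. The change from compound 2 to compound 1 is methoxy in place of hydrogen on an aromatic carbon and yields a 1.5-fold lower number from compound 2 to compound 1 (0.18 log units; within the scatter).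

Compound 3 `COc1cccc(-c2cc(C(=O)Nc3cc4ccc(Cc5ccccc5)c(C)c4oc3=O)ccc2OC)c1` is built on a different amide part; how its core differs from that of compound 2 is not broken down here. In this assay compound 3 gives 7110 nM, the lowest number of the three, and its distance to compound 1 and compound 2 lies beyond the scatter.

Compound 4 `COc1ccc(Cc2ccc3cc(NC(=O)c4ccc(OC)c(-c5cccc(OC)c5)c4)c(=O)oc3c2C)cc1` is not yet measured. It differs from compound 3 by methoxy in place of hydrogen on an aromatic carbon. This is the same kind of change as that from compound 2 to compound 1, but not the same: there the entering group sat ortho to a methoxymethoxy group and meta to a large group, here it sits para to a large group. Going by the values given here, the only precedent, from compound 2 to compound 1, stayed within the scatter, so only a small step is expected, a 1.2-fold lower number from compound 3 to compound 4 (0.07 log units; within the scatter), from compound 3 to compound 4. Compound 4 is therefore estimated at 6000 nM, expected to fall between 2500 nM and 15000 nM.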

Compound 4, half-maximal inhibitory concentration: > 100000 nM
Compound 4: no number, only a limit; the forecaster's own chance of this, stated with the estimate: 5%; middle value at least 16-fold (1.22 log units) from the limit.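

Methoxy in place of hydrogen on an aromatic carbon does not carry over as one effect between cores in this series: in this assay it gives an at least 14-fold higher number from compound 3 to compound 4 (1.14 log units; beyond the scatter), and the two steps differ: the same change on two cores in this assay, a 1.5-fold lower number (0.18 log units; within the scatter) from compound 2 to compound 1 and an at least 14-fold higher number (1.14 log units; beyond the scatter) from compound 3 to compound 4, at least 21-fold (1.33 log units) apart, beyond the scatter of two such steps. Compound 4 gives > 100000 nM, which is a limit of the assay and not a number, so the size of its step remains bounded on one side only: the limit of > 100000 nM in this assay, at which 1 of the 4 values shown sits. The methoxy also enters at a different place in each pair, so these data cannot separate the effect of the core from that of the place, and two pairs give no rule for the series.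

The compounds shown leave open whether a hydroxy group or a fluorine atom in place of the methoxy of compound 4 would give a measurable number in this assay. They also leave open whether an amine at that place would do so.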